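This account rests on a few compounds, and the source may have more. Where it says the series, first, only, none or still open, it means among the compounds named here.

Compound 1 `COc1ccc(-c2cn3ccnc3c(-c3ccc4ncn(C5CCCCC5)c4c3)n2)cc1` is the reference point of this small set: in a functional assay on MOLT-4 cells (Homo sapiens) for inhibition, read by sulforhodamine B assay, with a stated time of 48 h, tested at 10 uM (a higher number here means more inhibition at the concentration tested (going by the name of the read-out), a lower number less inhibition), compound 1 gives 82.8%. Compound 2 `Fc1ccc(-c2cn3ccnc3c(-c3ccc4ncn(C5CCCCC5)c4c3)n2)cc1` differs from it by fluoro in place of methoxy on an aromatic carbon and in this assay compound 2 gives 25.2%, so that a number 57.6 percentage points lower from compound 1 to compound 2 (beyond the scatter). Compound 3 `COc1ccccc1-c1cn2ccnc2c(-c2ccc3ncn(C4CCCCC4)c3c2)n1` keeps the same atoms as compound 1 but joined differently, (2-methoxyphenyl in place of 4-methoxyphenyl on an aromatic carbon), and in this assay compound 3 gives 22.4%, which means a number 60.4 percentage points lower from compound 1 to compound 3 (beyond the scatter). Between the two lower numbers the picture is level, since a number 2.8 percentage points lower from compound 2 to compound 3 (within the scatter).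

Compound 4 `Fc1ccccc1-c1cn2ccnc2c(-c2ccc3ncn(C4CCCCC4)c3c2)n1` has not yet been tested. It differs from compound 3 by fluoro in place of methoxy on an aromatic carbon. Among the measured compounds shown here, this is the same kind of change as the one from compound 1 to compound 2, but not the same: there the place was para to a large group, here it is ortho to a large group. The earlier step was large, a number 57.6 percentage points lower from compound 1 to compound 2 (beyond the scatter), yet compound 3 already sits low, so there is little room for a further fall. Compound 4 is therefore expected to give a low number in this assay, with an expected step of a number 7.4 percentage points lower from compound 3 to compound 4 (within the scatter), because compound 3 gives 22.4%. The estimate for compound 4 is 15%, expected to lie between 0% and 40%.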

Compound 4, a percentage reported as inhibition, at one concentration (the size of the read-out at that concentration, not a potency): 22.5%
For compound 4 the middle estimate is 7.5 percentage points below the measured one; the range from low to high includes it.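

In this assay, fluoro in place of methoxy does not behave alike on the two cores: the same change on two cores in this assay, a number 57.6 percentage points lower (beyond the scatter) from compound 1 to compound 2 and a number 0.1 percentage points higher (within the scatter) from compound 3 to compound 4, 57.7 percentage points apart, beyond the scatter of two such steps On the core carrying the 2-substituted phenyl the change leaves the reading level, with a number 0.1 percentage points higher from compound 3 to compound 4 (within the scatter), and moving the fluoro from 4-fluorophenyl to 2-fluorophenyl does the same, with a number 2.7 percentage points lower from compound 2 to compound 4 (within the scatter), while the step from 4-methoxyphenyl to 2-fluorophenyl is large, with a number 60.3 percentage points lower from compound 1 to compound 4 (beyond the scatter), so that among these four compounds only compound 1 stands apart. This rests on two pairs read at one concentration, so it shows that the large step of the first pair did not recur in the second, but it does not show why, nor how the change would behave on any further core.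

The compounds shown leave open whether the high number of compound 1 depends on methoxy itself or would persist with another group in its place on the 4-substituted phenyl. An amine, a hydroxyl or a longer chain such as ethoxy at that place would bear on this.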